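The source may report more compounds than this note shows. Statements on the series, on what has been measured and on what is new or still open speak of the compounds shown alone.

Of the compounds shown here, two in this set have been tested in an ADME assay on Vero cells (Chlorocebus sabaeus) for cytotoxicity; on this read-out lower numbers stand for higher toxicity in this test and higher numbers for lower toxicity in this test. Compound 1, `COc1ccc(-c2nn3c(NC4CCCC4)cccc3c2-c2ccnc(NC3CCCC3)n2)cc1`, reaches only a limit of the test: in this assay compound 1 gives > 100000 nM, which is a limit of the assay and not a measured number. Among the compounds with values here, compound 2, `COc1ccc(-c2nn3c(NC4CCCC4)ccnc3c2-c2ccnc(NC3CCCC3)c2)cc1`, is the only one with an actual number, and in this assay compound 2 gives 10000 nM. Within the data shown here, compounds 1 and 2 differ from each other in more than one place, so no single step connects them; what is known is simply (the limit of > 100000 nM in this assay, at which 1 of the 2 values shown sits), alongside the one measured number for compound 2.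

Compound 3, `c1ccc(-c2nn3c(NC4CCCC4)ccnc3c2-c2ccnc(NC3CCCC3)c2)cc1`, still has to be measured in this assay. It differs from compound 2 by one change: hydrogen in place of methoxy on an aromatic carbon. Among the measured compounds shown here, no measured pair in this set carries the same change, so there is no direct precedent for its size. The expectation is a step of modest size, so that the expected step is no change at the digits printed from compound 2 to compound 3 (within the scatter), within the usual scatter and in no firm direction. Compound 3 is therefore expected to give about 10000 nM in this assay, with a likely range from 4000 nM to 30000 nM.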

Compound 3, half-maximal cytotoxic concentration: 14000 nM
Compound 3: the middle estimate sits 1.4-fold (0.15 log units) below what was measured; measured number inside the range.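

In this assay, within the data shown here, the swap of 4-methoxyphenyl to phenyl gives a 1.4-fold higher number from compound 2 to compound 3 (0.15 log units; within the scatter) and so offers the first direct look at this position, on a six-membered aromatic ring of carbon only and para to a large group. For this one pair, methoxy and hydrogen at this position cannot be told apart in this test, so the two heavy atoms of the methoxy can go without the reading leaving the usual scatter. Nothing measured here gives a reason for this outcome.

As far as these compounds go, what other groups would do at the same place remains open, since an amine, a carboxylic acid or a longer chain such as butoxy could give a reading well away from those of compound 2 and compound 3. A single pair also cannot tell whether the same swap from methoxy to hydrogen would stay this small on a different core, or with other groups in place of the two cyclopentyl-bearing amines.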